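The source may report more compounds than this note shows. Statements on the series, on what has been measured and on what is new or still open speak of the compounds shown alone.

Series notes. Compound 1 `C=CCN(CC=C)C(=S)N/N=C(/C)c1ccc(F)cc1`, compound 2 `C=CCN(CC=C)C(=S)N/N=C(/C)c1ccccc1` and compound 3 `C=CCN(CC=C)C(=S)N/N=C(/C)c1ccc(O)cc1` share one core and differ only in a single group on the aromatic ring. In an ADME assay on Vero cells (Chlorocebus sabaeus) for cytotoxicity, read by MTT assay, with a stated time of 72 h (on this read-out lower numbers stand for higher toxicity in this test and higher numbers for lower toxicity in this test), compound 1 gives 214000 nM, compound 2 gives 229000 nM and compound 3 gives 216000 nM. Compound 2 holds the highest of the three numbers, but the spread is narrow: a 1.1-fold higher number from compound 1 to compound 2 (0.03 log units; within the scatter) and a 1.1-fold lower number from compound 2 to compound 3 (0.03 log units; within the scatter) both stay within the scatter, so no ordering among the three can be read from them.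

Compound 4 `C=CCN(CC=C)C(=S)N/N=C(/C)c1ccccc1O` has not yet been measured. It differs from compound 2 as follows: hydroxy in place of hydrogen on an aromatic carbon. The same kind of exchange is already on record once, as a 1.1-fold lower number from compound 2 to compound 3 (0.03 log units; within the scatter), though the place on the ring differs; that step was flat. Among the measured compounds shown here, no measured step in this set exceeds the scatter, so nothing beyond the scatter is expected from compound 2 to compound 4 in this assay; the expected step is a 1.0-fold lower number from compound 2 to compound 4 (0.01 log units; within the scatter). Compound 4 is therefore estimated at 225000 nM in this assay, with an expected range of 140000 nM to 350000 nM.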

Compound 4, half-maximal cytotoxic concentration: 216000 nM
The estimate for compound 4 lay 1.0-fold (0.02 log units) above the measured number; the range from low to high includes it.
By their numbers in this assay, from the lowest: compounds 1, 3, 4 and 2 (each within the scatter of the next).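

In this assay, hydroxy in place of hydrogen on an aromatic carbon ortho to a large group gives a 1.1-fold lower number from compound 2 to compound 4 (0.03 log units; within the scatter). The same exchange at the place it occupies in compound 3 gives a 1.1-fold lower number from compound 2 to compound 3 (0.03 log units; within the scatter), so the exchange now stays within the scatter at two places on the ring rather than one. No information is available on why the read-out stays flat at either place.

From the compounds shown here alone, whether an amine, a carboxylic acid or a methoxy group on this same aromatic carbon would also stay within the scatter remains open. The compounds shown also leave open whether any change away from the aromatic ring, on the rest of the shared core, would move the number beyond the scatter.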